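A Ring Swap and Its Expected Effect on Cell Toxicity

A few compounds are considered here, and "the series" means these few. Any claim that something is new, unique, unknown or untested is made for them only; others in the source may bear on it.

Among the compounds with values here, compound 1 `COC(=O)c1ccc(NCc2cncn2Cc2ccccc2C)cc1-c1ccccc1` is the only compound with a plain number here. In a toxicity assay on NIH3T3 cells (Mus musculus) for cytotoxicity, read by resazurin assay (a lower number here means that less compound is needed, a higher number that more compound is needed for the effect), compound 1 gives 10000 nM. Compound 2 `CCC(=O)c1ccc(NCc2cncn2Cc2ccc(-c3ccccc3)cc2)cc1-c1ccccc1` reaches only a limit, > 10000 nM, so no number is known for it (the limit of > 10000 nM in this assay, at which 1 of the 2 values shown sits). Compound 3 `COC(=O)c1ccc(NCc2cncn2Cc2cccc(N)c2)cc1-c1ccccc1` differs from compound 1 in one place: 3-aminophenyl in place of 2-methylphenyl on a saturated chain carbon bound to an aromatic nitrogen. Within the data shown here, no measured pair shows a single change of this kind, so there is no measured step to lean on. The expected step of no change at the digits printed from compound 1 to compound 3 (within the scatter) stays within the usual scatter. Compound 3 is expected to give about 10000 nM in this assay, within a range from 4000 nM to 25000 nM.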

Compound 3, half-maximal effective concentration: > 10000 nM
Compound 3: no number, only a limit; the forecaster's own chance of this, stated with the estimate: 45%; the middle value sits exactly at the limit.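

In this assay, 3-aminophenyl on this saturated chain carbon gives a number no lower from compound 1 to compound 3 (the limit leaves the size open), the only single-place comparison shown at this position. Going by these compounds, the value of compound 3 is a limit and not a number, so the swap did not bring the number down, but how far it rose, if at all, stays unknown. The comparison ends at the same ceiling that compound 2 reached: the limit of > 10000 nM in this assay, at which 2 of the 3 values shown sit.

The compounds shown leave open whether the amine or the missing methyl matters. They also leave open what a carboxylic acid or a longer chain would give at this place.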